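A Nitrile Replaces Fluorine on the Benzyl Arm

The source may report more compounds than this note shows. Statements on the series, on what has been measured and on what is new or still open speak of the compounds shown alone.

Three compounds share one core and carry a substituted benzyl group on a saturated chain carbon bound to an aromatic nitrogen: compound 1 `O=c1ccoc2cc(OCc3cn(Cc4ccccc4Br)nn3)ccc12`, compound 2 `O=c1ccoc2cc(OCc3cn(Cc4cccc(Br)c4)nn3)ccc12` and compound 3 `O=c1ccoc2cc(OCc3cn(Cc4ccc(F)cc4)nn3)ccc12`. In an ADME assay on L02 cells (Homo sapiens) for cytotoxicity, read by MTT assay, with a stated time of 48 h (a higher number here means a weaker inhibitor, a lower number a stronger inhibitor), compound 1 gives only a limit, > 300000 nM. Compound 2 likewise reaches only a limit, > 300000 nM, in this assay. Compound 3 also stands at a limit, > 300000 nM, in this assay. All three values sit at the limit of > 300000 nM in this assay, at which 3 of the 3 values shown sit. Hence the steps a step that the two limits leave unreadable from compound 1 to compound 2, a step that the two limits leave unreadable from compound 1 to compound 3 and a step that the two limits leave unreadable from compound 2 to compound 3 cannot be read. Compound 4 `N#Cc1cccc(Cn2cc(COc3ccc4c(=O)ccoc4c3)nn2)c1` differs from compound 3 by 3-cyanophenyl in place of 4-fluorophenyl on a saturated chain carbon bound to an aromatic nitrogen. Within the data shown here, no measured step gives a readable size for such a change, so the estimated step that the limit leaves unreadable from compound 3 to compound 4 is expected to stay within the scatter. Compound 4 is expected to give about 400000 nM, between 150000 nM and 1000000 nM, most likely again only a limit.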

Compound 4, half-maximal inhibitory concentration: > 300000 nM
Compound 4 was reported as a limit; the forecaster's own chance of this, stated with the estimate: 80%; the middle value is on the limit's open side.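

Compound 4 also gives only a limit in this assay, so its steps from compound 1, compound 2 and compound 3 cannot be read: the limit of > 300000 nM in this assay, at which 4 of the 4 values shown sit. The compounds shown leave open whether these benzyl groups differ at all in this assay.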